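A few compounds are considered here, and "the series" means these few. Any claim that something is new, unique, unknown or untested is made for them only; others in the source may bear on it.

Measured in a functional assay on A549/CDDP cells (Homo sapiens) for antiproliferative activity, read by MTT assay, with a stated time of 72 h; on this read-out lower numbers stand for stronger inhibition and higher numbers for weaker inhibition:
- compound 1 `COc1cc(/C=C/C(=O)/C=C/c2nc(C)c(C)nc2C)ccc1O`: 600 nM
- compound 2 `COc1cccc(/C=C/C(=O)/C=C/c2nc(C)c(C)nc2C)c1`: 3440 nM
- compound 3 `COc1ccc(/C=C/C(=O)/C=C/c2nc(C)c(C)nc2C)cc1`: 3610 nM

Compound 3 gives 3610 nM and compound 2 gives 3440 nM. These two values lie within the scatter of each other. Compound 1 gives 600 nM. The gap between compound 3 and compound 1 lies beyond the scatter. Next is compound 4 `COc1ccc(/C=C/C(=O)/C=C/c2nc(C)c(C)nc2C)cc1OC`, with this change: methoxy in place of hydrogen on an aromatic carbon, ortho to a methoxy group. Among the measured compounds shown here, the only measured step that bears on this is a 5.7-fold higher number from compound 1 to compound 2 (0.76 log units; beyond the scatter), where hydrogen replaces hydroxy. It concerns hydroxy rather than methoxy, so it is only a loose guide. A smaller shift towards stronger inhibition is expected in this assay. The expected step is a 1.8-fold lower number from compound 3 to compound 4 (0.26 log units; within the scatter). The estimate for compound 4 is 2000 nM, with an expected range of 750 nM to 4800 nM.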

Compound 4, half-maximal inhibitory concentration: 2440 nM
The estimate for compound 4 lay 1.2-fold (0.09 log units) below the measured number; the measured number falls inside the stated range.
By their numbers in this assay, from the lowest: compound 1; then compounds 4, 2 and 3 (each within the scatter of the next).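

In this assay, a second methoxy on the ring, ortho to a methoxy group, moves the number only within the scatter (a 1.5-fold lower number from compound 3 to compound 4 (0.17 log units; within the scatter)) and (a 1.4-fold lower number from compound 2 to compound 4 (0.15 log units; within the scatter)). Methyl in place of hydrogen on the oxygen gives a step beyond the scatter (a 4.1-fold higher number from compound 1 to compound 4 (0.61 log units; beyond the scatter)), so at this position methoxy does not reproduce the hydroxy of compound 1. No measurement available here accounts for this difference. Going by these compounds, whether an amine, a carboxylic acid or a longer chain such as ethoxy at that position would keep the number of compound 1 remains open.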